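Sulfonyl in place of sulfanyl: compound 1 to compound 4

A few compounds are considered here, and "the series" means these few. Any claim that something is new, unique, unknown or untested is made for them only; others in the source may bear on it.

In a functional assay on DU-145 cells (Homo sapiens) for inhibition, read by trypan blue exclusion, with a stated time of 96 h (a higher number here means a weaker inhibitor of growth, a lower number a stronger inhibitor of growth), compound 1 (`O=C(/C(=C\c1ccccc1OCc1ccccc1)Sc1ccc(F)cc1)c1ccc(Cl)cc1`) gives 1000 nM, the lowest of the three measured numbers and beyond the scatter from both others. Compound 2 (`COc1ccc(/C=C(\C(=O)c2ccc(Br)cc2)S(=O)(=O)c2ccc(Br)cc2)c(F)c1`) gives 10000 nM, and compound 3 (`COc1ccsc1/C=C(\C(=O)c1ccc(Br)cc1)S(=O)(=O)Cc1ccc(Cl)cc1`) gives 50000 nM. Within the data shown here, these three compounds differ in more than one place, so the series has no measured single-change step.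

Compound 4 (`O=C(/C(=C\c1ccccc1OCc1ccccc1)S(=O)(=O)c1ccc(Br)cc1)c1ccc(Cl)cc1`) keeps the core of compound 1 and changes one group: (4-bromophenyl)sulfonyl in place of (4-fluorophenyl)sulfanyl on a double-bonded chain carbon bound to a carbonyl carbon and a double-bonded chain carbon. It has (4-bromophenyl)sulfonyl in place of (4-fluorophenyl)sulfanyl on a double-bonded chain carbon bound to a carbonyl carbon and a double-bonded chain carbon.

Among the measured compounds shown here, the only guide is indirect: compound 2, which also carries (4-bromophenyl)sulfonyl, gives 10000 nM but differs from compound 4 elsewhere too. A moderate rise in the number is therefore expected in this assay, and the estimated change is a 4.0-fold higher number from compound 1 to compound 4 (0.60 log units; beyond the scatter). For compound 4 the estimated value is 4000 nM, with an expected range from 1000 nM to 20000 nM.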

Compound 4, concentration for 50% growth inhibition: 1000 nM
Estimate against measurement, compound 4: 4.0-fold (0.60 log units) above; the range from low to high includes it.
By their numbers in this assay, from the lowest: compounds 1 and 4 (each within the scatter of the next); then compound 2; then compound 3.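

In this assay, among these compounds, (4-bromophenyl)sulfonyl in place of (4-fluorophenyl)sulfanyl on a double-bonded chain carbon bound to a carbonyl carbon and a double-bonded chain carbon gives no change at the digits printed from compound 1 to compound 4 (within the scatter), the first single-place step. On the core of compound 1, this position therefore carries either group with no difference beyond the scatter, even though the two groups differ in heavy atoms and hydrogen-bond acceptors. No measured data on hand account for this result.

On these data alone, the step alters the sulfur group and the ring halogen together, so the separate effects of sulfonyl versus sulfanyl and of bromine versus fluorine remain open. Also open, as far as these compounds go, is how this position responds to a group of a different kind, such as an amine or a carboxylic acid.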